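Aryl hydrazone series: 2-chloro-4-fluorophenyl replacing trimethylphenyl

The compounds below may be only part of what the source reports. "The series", "measured", "known", "first", "only" and "open" are said of these compounds alone.

Of the compounds shown here, two have numbers so far, both in a functional assay on PC-3 cells (Homo sapiens) for antiproliferative activity, read by MTT assay; on this read-out higher numbers stand for weaker inhibition and lower numbers for stronger inhibition. Compound 1 `Cn1c(=O)c(=O)n(C2CCCC2)c2nc(N/N=C/c3ccc(O)c(F)c3)ncc21` gives 85200 nM in this assay. Among the measured compounds shown here, compound 2 `Cc1cc(C)c(/C=N/Nc2ncc3c(n2)n(C2CCCC2)c(=O)c(=O)n3C)c(C)c1` gives 13900 nM in this assay, the lowest of the two numbers; the only step in the set, a 6.1-fold lower number from compound 1 to compound 2 (0.79 log units; beyond the scatter), separates it from compound 1.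

Compound 3 `Cn1c(=O)c(=O)n(C2CCCC2)c2nc(N/N=C/c3ccc(F)cc3Cl)ncc21` is not yet measured. It differs from compound 2 in one place: 2-chloro-4-fluorophenyl in place of 2,4,6-trimethylphenyl on a carbon with a double bond to nitrogen. For the measured compounds named here, no measured step covers this exact change. Going by the values given here, the one step at hand, from compound 1 to compound 2, swaps a different aryl group at the same carbon and is modest in size, so the only guidance is that the aryl group at this position moves the number by a modest amount in this assay. Compound 3 is therefore expected to land between the two measured numbers, a step of a 1.8-fold higher number from compound 2 to compound 3 (0.25 log units; within the scatter) from compound 2. The estimate for compound 3 in this assay is 25000 nM, with a range from 8000 nM to 80000 nM.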

Compound 3, half-maximal inhibitory concentration: 15200 nM
For compound 3 the middle estimate is 1.6-fold (0.22 log units) above the measured one; measured number inside the range.
By their numbers in this assay, from the lowest: compounds 2 and 3 (each within the scatter of the next); then compound 1.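

Notes on the aryl group on the carbon with a double bond to nitrogen: in this assay the exchange of 2,4,6-trimethylphenyl for 2-chloro-4-fluorophenyl gives a 1.1-fold higher number from compound 2 to compound 3 (0.04 log units; within the scatter) and so does not separate these two groups, even though they share no substituent. Among the compounds shown here, the gap to compound 1 is also seen a second time, as a 5.6-fold lower number from compound 1 to compound 3 (0.75 log units; beyond the scatter) sits alongside a 6.1-fold lower number from compound 1 to compound 2 (0.79 log units; beyond the scatter) and leaves 3-fluoro-4-hydroxyphenyl as the one group of the three set apart, and the only one carrying a hydroxy group. No separate data bear on the reason for these numbers.

For the compounds shown here, with only three aryl groups in view, the set cannot say whether the hydroxy group alone accounts for the gap to compound 1, or whether the fluorine in that group or the way the substituents are arranged on the ring also contributes. Going by these compounds, how an unsubstituted phenyl, or an aryl group bearing a dimethylamino group or a carboxylic acid, would compare at this carbon remains open, as does whether the flat result between compound 2 and compound 3 would hold on another cell line.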